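Swapping a chlorine position on a benzyl sulfur arm

This account rests on a few compounds, and the source may have more. Where it says the series, first, only, none or still open, it means among the compounds named here.

Of the compounds shown here, three have been tested in a functional assay on the whole organism (artery, strain albino) with Rattus norvegicus as the target, with a stated time of 120 min, at a dose of 10 mg/kg by the oral route; on this read-out higher numbers stand for more inhibition at the one dose given (going by the name of the read-out) and lower numbers for less inhibition. Compound 1, with the structure `COc1ccc(C2N=C(SCc3cccc(Cl)c3)NC(C)=C2C(=O)Nc2ccc(F)cc2)cc1OC`, gives 10.8% in this assay. Compound 2, with the structure `COc1ccc(C2N=C(SCc3ccc(Cl)cc3)NC(C)=C2C(=O)Nc2ccc(F)cc2)cc1OC`, gives 15.5% in this assay and differs from compound 1 only in one respect: 4-chlorophenyl in place of 3-chlorophenyl on a saturated chain carbon bound to a sulfur. This change moves the read-out a number 4.7 percentage points higher from compound 1 to compound 2 (within the scatter), so the two numbers cannot be told apart with confidence. Compound 3, with the structure `CC1=C(C(=O)Nc2ccc(Br)cc2)C(c2ccc(Cl)cc2Cl)N=C(SCc2cccc(Cl)c2)N1`, sits on a different core, and the difference between its core and that of compound 1 is not broken down here. In this assay compound 3 gives 8.8%, a number within the scatter of both compound 1 and compound 2, so the three numbers are level within the scatter and none can be separated from another with confidence.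

Compound 4, with the structure `CC1=C(C(=O)Nc2ccc(Br)cc2)C(c2ccc(Cl)cc2Cl)N=C(SCc2ccc(Cl)cc2)N1`, has not yet been measured. It relates to compound 3 exactly as compound 2 relates to compound 1: 4-chlorophenyl in place of 3-chlorophenyl on a saturated chain carbon bound to a sulfur. The place of the change is described in the same words for both pairs, so this is the same change made on a different core. Within the data shown here, the only guide to its size is the earlier pair, where the step was within the scatter. On that basis the step from compound 3 to compound 4 is expected to be a number 4.2 percentage points higher from compound 3 to compound 4 (within the scatter) in this assay. Compound 4 is therefore estimated to give 13%. The expected value for compound 4 should fall between 2% and 25%.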

Compound 4, a percentage reported as inhibition, in the whole organism at one dose (the size of the read-out at that dose, not a potency): 17.5%
For compound 4 the middle estimate is 4.5 percentage points below the measured one; low and high end bracket the measured number.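

In this assay, putting 4-chlorobenzyl in place of 3-chlorobenzyl on the sulfur of the second core gives a number 8.7 percentage points higher from compound 3 to compound 4 (within the scatter), so this pair cannot be told apart with confidence, just as the earlier pair could not. Set side by side, the two steps show no detectable difference between the cores, which means that nothing here suggests the core alters the outcome of this swap: the same change on two cores in this assay, a number 4.7 percentage points higher (within the scatter) from compound 1 to compound 2 and a number 8.7 percentage points higher (within the scatter) from compound 3 to compound 4, 4 percentage points apart, within the scatter of two such steps

This agreement does not show that the two cores respond identically, and it does not show that the swap has a real effect on either core, as each step lies within the scatter. Two pairs tested at a single dose also say nothing about potency, and they cannot establish a rule for other cores in the series.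

Going by these compounds, all four compounds carry a chlorine on the benzyl ring, so it remains open whether a carboxylic acid or an amine in its place would move the read-out beyond the scatter. On these data alone, it is equally open whether a longer chain between the sulfur and the ring would do so.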